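The source may report more compounds than this note shows. Statements on the series, on what has been measured and on what is new or still open speak of the compounds shown alone.

Compound 2 `CCSC(=O)C1=C(C)NC(=O)NC1c1ccco1` gives 29% in an assay on membranes from HEK293 cells for displacement of a labelled ligand from adenosine receptor A2b (Homo sapiens), read by scintillation counting, with a stated time of 30 min, tested at 1 uM (on this read-out higher numbers stand for more inhibition at the one concentration tested (going by the name of the read-out) and lower numbers for less inhibition), and stands second highest of the three numbers measured. Compound 1 `CCN(CC)C(=O)C1=C(C)NC(=O)NC1c1ccco1` gives 31% in this assay, and a number 2 percentage points lower from compound 1 to compound 2 (within the scatter). Compound 3 `CCSC(=O)C1=C(C)NC(=O)NC1c1ccsc1` gives 17% in this assay, and a number 12 percentage points lower from compound 2 to compound 3 (beyond the scatter). Compound 4 `CC1=C(C(=O)OC2CCCCC2)C(c2ccco2)NC(=O)N1` differs from compound 2 by cyclohexyloxy in place of ethylsulfanyl on a carbonyl carbon. For the measured compounds named here, the one measured step at the carbonyl carbon, a number 2 percentage points lower from compound 1 to compound 2 (within the scatter), stayed within the scatter; the only step beyond the scatter, a number 12 percentage points lower from compound 2 to compound 3 (beyond the scatter), sits on the saturated ring carbon and does not bear on this change. Going by the values given here, no measured compound carries cyclohexyloxy, so no step beyond the scatter in this assay is expected from the change. Compound 4 is therefore estimated at 30%, with a range from 15% to 45%. The expected step is a number 1 percentage points higher from compound 2 to compound 4 (within the scatter).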

Compound 4, a percentage reported as inhibition, at one concentration (the size of the read-out at that concentration, not a potency): 1%
The estimate for compound 4 lay 29 percentage points above the measured number; the measured number lies below the stated range.
By their numbers in this assay, from the lowest: compound 4; then compound 3; then compounds 2 and 1 (each within the scatter of the next).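

Cyclohexyloxy on the carbonyl carbon gives a number 28 percentage points lower from compound 2 to compound 4 (beyond the scatter) and a number 30 percentage points lower from compound 1 to compound 4 (beyond the scatter) in this assay and so shows that this position is not indifferent to the group it carries. Ethylsulfanyl and diethylamino alone had left that unseen, as their values lie within the scatter of each other. No measurement shown gives a reason for the drop.

On these data alone, whether the ring or the oxygen of cyclohexyloxy goes with the drop stays open, and so does the reading for an ethoxy or a phenoxy group on the same carbonyl carbon.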